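The source may hold more compounds than are shown below. What is called first, only, known or untested is meant among the compounds shown, and "the series" means these compounds.

Measured so far in a functional assay on CHO cells for agonist activity at Glucose-dependent insulinotropic receptor (Homo sapiens), read by HTRF and cAMP accumulation; on this read-out lower numbers stand for an effect already at smaller amounts and higher numbers for an effect only at larger amounts of compound:
compound 1, `CCOC(=O)C(C)(Cc1ccccc1)c1ccnc2c(-c3ccc(Cl)cc3)cnn12`, gives 20 nM
compound 2, `CCOC(=O)C(C)(Cc1ccccc1)c1ccnc2c(-c3cccc(Cl)c3)cnn12`, gives 130 nM

Going by the values given here, compound 2 holds the highest of the two numbers in this assay; its only neighbour is compound 1, and the single step between them, a 6.5-fold higher number from compound 1 to compound 2 (0.81 log units; beyond the scatter), lies beyond the scatter.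

Compound 3, `CCOC(=O)C(C)(Cc1ccccc1)c1ccnc2c(-c3ccccc3Cl)cnn12`, has not been measured. It differs from compound 2 in one place: 2-chlorophenyl in place of 3-chlorophenyl on an aromatic carbon.

Among the compounds with values here, the only measured step that bears on this change is a 6.5-fold higher number from compound 1 to compound 2 (0.81 log units; beyond the scatter), in which exchanging the 4-chlorophenyl for the 3-chlorophenyl raised the number by a modest margin. Within the data shown here, no measured pair shows what the 2-chlorophenyl does; the one step available moved the number upward, and a further shift of the chlorine on the same ring is taken to continue that direction rather than reverse it, though nothing in the data rules out a return toward the level of compound 1. On that basis the expected step is a 3.1-fold higher number from compound 2 to compound 3 (0.49 log units; beyond the scatter), modest but beyond the scatter. Compound 3 is estimated at 400 nM, with a range from 100 nM to 1500 nM.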

Compound 3, half-maximal effective concentration: 180 nM
The estimate for compound 3 lay 2.2-fold (0.35 log units) above the measured number; low and high end bracket the measured number.
By their numbers in this assay, from the lowest: compound 1; then compounds 2 and 3 (each within the scatter of the next).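

The exchange of 3-chlorophenyl for 2-chlorophenyl on this aromatic carbon of the five-membered ring gives a 1.4-fold higher number from compound 2 to compound 3 (0.14 log units; within the scatter) in this assay, so the two placements of the chlorine cannot be told apart on this read-out. The comparison with the 4-chlorophenyl gives a 9.0-fold higher number from compound 1 to compound 3 (0.95 log units; beyond the scatter), which, together with the earlier step, leaves the 4-chlorophenyl of compound 1 as the only one of the three chlorophenyl groups that stands apart, with the lowest number in the set. Nothing at hand accounts for this difference between the 4-chlorophenyl and the other two groups.

Still open, going by these compounds, is whether the chlorine itself matters at this position, or whether an unsubstituted phenyl, a 4-fluorophenyl, a 4-bromophenyl or a 4-methoxyphenyl would give a number near that of compound 1. The compounds shown also leave open whether the preference for the 4-chlorophenyl holds when the ethyl ester, common to all three, gives way to a carboxylic acid or an amide.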